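Sulfamate series note: furan-2-yl to (dimethylamino)methyl

This account rests on a few compounds, and the source may have more. Where it says the series, first, only, none or still open, it means among the compounds named here.

Of the compounds shown here, three on the shared core have been measured. In an assay on HEK293 cells for inhibition of Steryl-sulfatase (Homo sapiens), tested at 0.1 uM (a higher number here means a stronger effect of the compound at the concentration tested, a lower number a weaker effect), compound 1 `NS(=O)(=O)Oc1ccc2c(c1)CN(C(=O)c1cccc(N3CCC(N4CCCCC4)CC3)c1)CC2` gives 0% and compound 2 `NS(=O)(=O)Oc1ccc2c(c1)CN(C(=O)c1cccc(N3CCN(c4ncccn4)CC3)c1)CC2` gives 1.6%. Compound 3 `NS(=O)(=O)Oc1ccc2c(c1)CN(C(=O)c1ccc(N(Cc3ccccc3)Cc3ccco3)cc1)CC2` gives 90.8% in this assay, the highest of the three and beyond the scatter from both others. Compound 4 `CN(C)CCN(Cc1ccccc1)c1ccc(C(=O)N2CCc3ccc(OS(N)(=O)=O)cc3C2)cc1` differs from compound 3 in one place: (dimethylamino)methyl in place of furan-2-yl on a saturated chain carbon bound to a nitrogen on an aromatic ring. Going by the values given here, no step between measured compounds is available to size this change, and the low values of compound 1 and compound 2 show that the rest of the series sits far below compound 3. A downward step is expected, a number 45.8 percentage points lower from compound 3 to compound 4 (beyond the scatter), though compound 4 is estimated to keep part of the inhibition seen for compound 3. Compound 4 is expected to give 45%, within 10% to 85%.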

Compound 4, a percentage reported as inhibition, at one concentration (the size of the read-out at that concentration, not a potency): 13.9%
The estimate for compound 4 lay 31.1 percentage points above the measured number, within the range that was stated.
By their numbers in this assay, from the lowest: compounds 1 and 2 (each within the scatter of the next); then compound 4; then compound 3.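

In this assay, going by these compounds alone, replacing furan-2-yl with (dimethylamino)methyl on this saturated chain carbon gives a number 76.9 percentage points lower from compound 3 to compound 4 (beyond the scatter), the only single-place step available. With the rest of compound 3 unchanged, the high inhibition at this concentration is therefore sensitive to the group at this place. Nothing available explains the size of the step.

Going by these compounds, whether the loss tracks the missing furan ring or the incoming amine stays open. A phenyl ring or a plain propyl chain at this place would help separate the two.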